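Working notes: from compound 2 to compound 3

The compounds below may be only part of what the source reports. "The series", "measured", "known", "first", "only" and "open" are said of these compounds alone.

- compound 1 `COc1cc(/C=C(\C#N)C(=O)N/N=C(\C)c2c(O)c3ccc(O)cc3oc2=O)cc(OC)c1OC` gives 14600 nM
- compound 2 `C/C(=N\NC(=O)/C(C#N)=C/c1ccc(N(C)C)cc1)c1c(O)c2ccc(O)cc2oc1=O` gives 6090 nM

In a functional assay on SK-N-SH cells (Homo sapiens) for cytotoxicity, read by MTT assay, with a stated time of 24 h (on this read-out higher numbers stand for weaker inhibition and lower numbers for stronger inhibition), compound 2 holds the lowest of the two numbers, and compound 1 lies higher, beyond the scatter. Compound 3 `C/C(=N\NC(=O)/C(C#N)=C/c1ccccc1Cl)c1c(O)c2ccc(O)cc2oc1=O` carries 2-chlorophenyl in place of 4-(dimethylamino)phenyl on a double-bonded chain carbon bound to a double-bonded chain carbon. Among the compounds with values here, no measured step covers this change, so only a small move toward a higher number in this assay is expected, within the scatter. The estimated step is a 1.6-fold higher number from compound 2 to compound 3 (0.22 log units; within the scatter). For compound 3 the expected value is 10000 nM, with an estimated range from 3500 nM to 28000 nM.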

Compound 3, half-maximal inhibitory concentration: 14000 nM
For compound 3 the middle estimate is 1.4-fold (0.15 log units) below the measured one; the measured number falls inside the stated range.
By their numbers in this assay, from the lowest: compound 2; then compounds 3 and 1 (each within the scatter of the next).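

Within this assay the group on a double-bonded chain carbon bound to a double-bonded chain carbon now has a single-change comparison, the only one in the series so far. Placing 2-chlorophenyl in place of 4-(dimethylamino)phenyl gives a modest shift beyond the scatter (a 2.3-fold higher number from compound 2 to compound 3 (0.36 log units; beyond the scatter)), so the read-out is sensitive to the change at this position. Nothing available explains this shift. Still open, from the compounds shown here alone, is whether the shift follows the loss of dimethylamino or the gain of chlorine. A plain phenyl or a carboxylic acid-bearing phenyl in this place could separate those two readings.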